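The source may report more compounds than this note shows. Statements on the series, on what has been measured and on what is new or still open speak of the compounds shown alone.

Compound 1, `CCN(c1ccccc1C)S(=O)(=O)c1cc(Cl)ccc1Cl`, was examined in an ADME assay on A549 cells (Homo sapiens) for cytotoxicity, read by MTT assay; on this read-out higher numbers stand for lower toxicity in this test and lower numbers for higher toxicity in this test. In this assay compound 1 gives > 25000 nM, which is a limit of the assay and not a measured number. Compound 2, `Cc1ccccc1N(C)S(=O)(=O)c1cc(Cl)ccc1Cl`, differs from compound 1 by a step that the two limits leave unreadable from compound 1 to compound 2. In this assay compound 2 gives > 5000 nM, which is likewise a limit and not a number. Because the limit of > 25000 nM in this assay, at which 1 of the 2 values shown sits, and the limit of > 5000 nM in this assay, at which 1 of the 2 values shown sits, are both limits, the size of the step between these two compounds cannot be read, and compound 1 stands only at a limit of the assay.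

Compound 3, `CCN(c1ccc(F)cc1)S(=O)(=O)c1cc(Cl)ccc1Cl`, has not yet been measured in this assay. It differs from compound 1 by 4-fluorophenyl in place of 2-methylphenyl on a sulfonamide nitrogen. Within the data shown here, no measured step bears on this change at the sulfonamide nitrogen, and the only measured step in the set has a size that could not be read. The account therefore expects no step beyond the scatter, and estimates the step from compound 1 to compound 3 as a step that the limit leaves unreadable from compound 1 to compound 3. In this assay compound 3 is expected to give 30000 nM, within an estimated range from 8000 nM to 100000 nM, with a limit rather than a number the more likely outcome.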

Compound 3, half-maximal cytotoxic concentration: > 5000 nM
Compound 3 was reported as a limit; the forecaster's own chance of this, stated with the estimate: 75%; the middle value lies beyond the limit too.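

Compound 1 and compound 3 both stand only at limits in this assay, and the size of the step between them cannot be read. The compounds shown leave open whether compound 1, compound 2 or compound 3 would give a measured number in this assay, and what either change at the sulfonamide nitrogen does to it.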